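This account rests on a few compounds, and the source may have more. Where it says the series, first, only, none or still open, it means among the compounds named here.

Compound 1 `CCCC(=O)N1CCC(CN2CC[C@H](NC(=O)c3cc(Cl)c(N)cc3OC)[C@H](OC)C2)CC1` stands second highest of the three numbers in an assay on COS-7 cells for displacement of a labelled ligand from 5-hydroxytryptamine receptor 4 (Homo sapiens), read by scintillation counting, with a stated time of 30 min (on this read-out higher numbers stand for weaker inhibition and lower numbers for stronger inhibition), where compound 1 gives 178 nM. Compound 3 `COc1cc(N)c(Cl)cc1C(=O)N[C@H]1CCN(CC2CCN(C(=O)CC(C)C)CC2)C[C@H]1OC` gives 78 nM, and compound 2 `COc1cc(N)c(Cl)cc1C(=O)N[C@H]1CCN(CCCn2cncn2)C[C@H]1OC` gives 1270 nM. Compound 4 `COc1cc(N)c(Cl)cc1C(=O)N[C@H]1CCN(CC2CCN(C(C)=O)CC2)C[C@H]1OC` differs from compound 1 by hydrogen in place of ethyl on a saturated chain carbon bound to a carbonyl carbon. The step with a methyl added on the acyl chain gave a 2.3-fold lower number from compound 1 to compound 3 (0.36 log units; beyond the scatter), so shortening that chain points the other way; the step of a 7.1-fold higher number from compound 1 to compound 2 (0.85 log units; beyond the scatter) changes a different part and bears less on this one. A modest rise in the number is therefore expected, about a 1.7-fold higher number from compound 1 to compound 4 (0.23 log units; within the scatter). Compound 4 is estimated at 300 nM, within a range from 120 nM to 750 nM.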

Compound 4, half-maximal inhibitory concentration: 592 nM
Estimate against measurement, compound 4: 2.0-fold (0.30 log units) below, and the stated range covers the measured number.
By their numbers in this assay, from the lowest: compound 3; then compound 1; then compound 4; then compound 2.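

In this assay, shortening the acyl chain to acetyl loses more than the added methyl gained (a 3.3-fold higher number from compound 1 to compound 4 (0.52 log units; beyond the scatter)), and the gap across this position widens further against the branched chain of compound 3 (a 7.6-fold higher number from compound 3 to compound 4 (0.88 log units; beyond the scatter)), so among compounds 4, 1 and 3 the number falls as the acyl chain grows, with none going against this. The 1-acetylpiperidin-4-yl group still gives a lower number than the 2-(1H-1,2,4-triazol-1-yl)ethyl group (a 2.1-fold lower number from compound 2 to compound 4 (0.33 log units; beyond the scatter)). No measured evidence explains these shifts.

From the compounds shown here alone, whether a longer chain would lower the number further remains open. So does the effect of an amine or a hydroxyl group on the acyl chain.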